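The compounds below may be only part of what the source reports. "The series", "measured", "known", "first", "only" and "open" are said of these compounds alone.

Measured compounds:
- compound 1 `O=C(OC1(C(=O)Nc2ccc([N+](=O)[O-])cc2)CCCCC1)c1ccc(C(F)(F)F)cc1`: 29.1 nM
- compound 2 `O=C(OC1(C(=O)Nc2ccc([N+](=O)[O-])cc2)CCCCC1)c1ccccc1`: 734 nM

Within the data shown here, in a functional assay on HepG2 cells (Homo sapiens) for inhibition, read by MTT assay, with a stated time of 72 h (on this read-out lower numbers stand for stronger inhibition and higher numbers for weaker inhibition), compound 2 stands as the higher of the two numbers; its only neighbour is compound 1, and the step of a 25-fold higher number from compound 1 to compound 2 (1.40 log units; beyond the scatter) separates them, a large one that lies beyond the scatter. That step changed only the substituent on the aromatic ring of the ester part, and it alone bears on what follows.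

Compound 3 `CC(=O)OC1(C(=O)Nc2ccc([N+](=O)[O-])cc2)CCCCC1` has not been measured. Among the measured compounds shown here, it differs from compound 2 by methyl in place of phenyl on a carbonyl carbon, so the ester part that the one measured step already showed to matter is now reduced further. Since the step from compound 1 to compound 2 was a 25-fold higher number from compound 1 to compound 2 (1.40 log units; beyond the scatter), a further step in the same direction, toward a higher number, is expected. For the measured compounds named here, its size is uncertain; no measured pair covers this exact change.

Compound 3 is therefore estimated at 3000 nM in this assay, between 800 nM and 15000 nM, an expected step of a 4.1-fold higher number from compound 2 to compound 3 (0.61 log units; beyond the scatter).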

Compound 3, half-maximal inhibitory concentration: 519 nM
Beside the measured number, compound 3's estimate is 5.8-fold (0.76 log units) above it; the whole stated range lies above it.
By their numbers in this assay, from the lowest: compound 1; then compounds 3 and 2 (each within the scatter of the next).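

In this assay the change from benzoyl to acetyl gives a 1.4-fold lower number from compound 2 to compound 3 (0.15 log units; within the scatter), so at this carbonyl carbon the plain phenyl ring and a single methyl cannot be told apart. A bare aromatic ring at this place therefore brings no measurable gain over methyl, and among these three compounds only the 4-(trifluoromethyl)phenyl group of compound 1 stands apart, with an 18-fold higher number from compound 1 to compound 3 (1.25 log units; beyond the scatter). Nothing measured here gives a reason for this.

As far as these compounds go, it remains open whether another group on the ring, such as chlorine or methoxy, would match trifluoromethyl. From the compounds shown here alone, it is equally open whether a longer chain such as butyl in place of methyl would stay level with compound 2 and compound 3 or move toward compound 1.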